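A Repeated Urea Aryl Swap and Its Expected Gain

This account rests on a few compounds, and the source may have more. Where it says the series, first, only, none or still open, it means among the compounds named here.

Three compounds have been measured in a functional assay on NCI-H1581 cells (Homo sapiens) for inhibition, read by MTT assay, with a stated time of 48 h, tested at 10 uM; a lower number here means less inhibition, a higher number more inhibition at the concentration tested (going by the name of the read-out):
Compound 1, `COc1cc(NC(=O)Nc2cc(Nc3cccc(C(C)(C)C)c3)ncn2)cc(OC)c1`, gives 35.1%.
Compound 2, `COc1cc(Br)ccc1Nc1cc(NC(=O)Nc2c(Cl)cccc2Cl)ncn1`, gives 47.3%.
Compound 3, `COc1cc(NC(=O)Nc2cc(Nc3ccc(Br)cc3OC)ncn2)cc(OC)c1`, gives 20.1%.

Compounds 2 and 3 differ in a single place, the group on the amide-type nitrogen: 2,6-dichlorophenyl in place of 3,5-dimethoxyphenyl on an amide-type nitrogen. In this assay this change made a step of a number 27.2 percentage points higher from compound 3 to compound 2 (beyond the scatter). Compounds 1 and 3 share the urea end but carry different groups on the ring nitrogen: 3-(tert-butyl)phenyl in place of 4-bromo-2-methoxyphenyl on a nitrogen on an aromatic ring. Going the other way, the step was a number 15 percentage points lower from compound 1 to compound 3 (beyond the scatter). Going by the values given here, no single-point step links compound 1 and compound 2; their values simply show compound 2 standing higher than compound 1 by a gap outside the usual scatter.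

Compound 4, `CC(C)(C)c1cccc(Nc2cc(NC(=O)Nc3c(Cl)cccc3Cl)ncn2)c1`, has not yet been measured. It arises from compound 1 by 2,6-dichlorophenyl in place of 3,5-dimethoxyphenyl on an amide-type nitrogen. The place of the change is worded exactly as for the step from compound 3 to compound 2, so it is the same change, made on the core of compound 1 instead of the core of compound 3. The expected step is a number 24.9 percentage points higher from compound 1 to compound 4 (beyond the scatter), set beside the measured a number 27.2 percentage points higher from compound 3 to compound 2 (beyond the scatter); this rests on that one measured pair alone, and a second pair is too little to call a pattern. Compound 4 is therefore expected to give about 60% in this assay, estimated to fall between 42% and 78%.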

Compound 4, a percentage reported as inhibition, at one concentration (the size of the read-out at that concentration, not a potency): 64.3%
Beside the measured number, compound 4's estimate is 4.3 percentage points below it; the measured number falls inside the stated range.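

In this assay, putting 2,6-dichlorophenyl in place of 3,5-dimethoxyphenyl on the amide-type nitrogen of compound 1 produced a step of a number 29.2 percentage points higher from compound 1 to compound 4 (beyond the scatter), so the change that raised the number on one core also raised it on a second core. Set beside the earlier step, the size of the change held from one core to the other: the same change on two cores in this assay, a number 27.2 percentage points higher (beyond the scatter) from compound 3 to compound 2 and a number 29.2 percentage points higher (beyond the scatter) from compound 1 to compound 4, 2 percentage points apart, within the scatter of two such steps. This shows that, for these two pairs, the gain from the swap did not depend on whether the nitrogen on the aromatic ring carried 3-(tert-butyl)phenyl or 4-bromo-2-methoxyphenyl, but it does not establish a rule for the series, since two cores are a small sample, and readings at one concentration give the size of the inhibition rather than a potency, while nothing here explains why the swap raises the number.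

The compounds shown leave open whether the same gain would survive with a simple alkyl chain or an amine on the nitrogen on the aromatic ring in place of these aryl groups. They also leave open which part of 2,6-dichlorophenyl carries the gain, as no phenyl with a single chlorine, a plain phenyl or a 2,6-dimethylphenyl stands among them.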